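The source may report more compounds than this note shows. Statements on the series, on what has been measured and on what is new or still open speak of the compounds shown alone.

In a physicochemical assay for solubility, with a stated time of 24 h, at pH 2.2 (on this read-out higher numbers stand for higher solubility and lower numbers for lower solubility), the measured compounds stand as follows.
Compound 1, `O=C(NCCO)c1ccc2ccc(C(=O)c3ccccc3)c-2cc1`, gives 14 ug/mL.
Compound 2, `CN(C)C(=O)c1cn(C)c2ccccc12`, gives > 51 ug/mL, which is a limit of the assay and not a number.
Compound 3, `NC(=O)C1CCN(C(=O)c2cccc3ccccc23)CC1`, gives > 70 ug/mL, again a limit rather than a number.

Compound 2 therefore sits at the limit of > 51 ug/mL in this assay, at which 1 of the 3 values shown sits, so its true solubility is known only to lie beyond that limit, not as a number. Compound 4, `COC(=O)c1ccc2c(C(=O)N(C)C)cn(C)c2c1`, differs from compound 2 by a single change: methoxycarbonyl in place of hydrogen on an aromatic carbon. Among the measured compounds shown here, no pair of measured compounds shows this change, so no measured step guides the estimate. A fall in this assay is expected, though it may be no larger than the usual scatter. The expected step is an at least 1.7-fold lower number from compound 2 to compound 4 (0.23 log units; that floor lies within the scatter). Compound 4 is estimated at 30 ug/mL, within 10 ug/mL to 90 ug/mL.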

Compound 4, solubility: 50 ug/mL
Compound 4: the middle estimate sits 1.7-fold (0.22 log units) below what was measured, and the stated range covers the measured number.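

Putting methoxycarbonyl in place of hydrogen on this aromatic carbon gives an at least 1.0-fold lower number from compound 2 to compound 4 (0.00 log units; that floor lies within the scatter) in this assay. With this group in place, the read-out is a number rather than a limit, so this core now has a measured value to compare against. The true size of the step stays unknown because compound 2 carries only a limit: the limit of > 51 ug/mL in this assay, at which 1 of the 4 values shown sits.

From the compounds shown here alone, whether a carboxylic acid, an amine or a longer chain on this carbon would give a different number remains open. So does the effect of methoxycarbonyl on the other carbons of this ring.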